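The source may hold more compounds than are shown below. What is called first, only, known or untested is meant among the compounds shown, and "the series" means these compounds.

Measured compounds:
compound 1 `CCOC(=O)C1=Cc2ccccc2OC1(OCc1cc(-c2ccc(OC)cc2)no1)C(F)(F)F`, > 150000 nM in a functional assay on HeLa cells (Homo sapiens) for inhibition, read by MTT assay, with a stated time of 24 h (a lower number here means a stronger inhibitor, a higher number a weaker inhibitor), a limit;
compound 2 `CCOC(=O)C1=Cc2ccccc2OC1(OCc1cn(CC(=O)Nc2cccc(F)c2)nn1)C(F)(F)F`, > 150000 nM in this assay, a limit;
compound 3 `CCOC(=O)C1=Cc2ccccc2OC1(OCc1cc(-c2ccc(Cl)cc2)no1)C(F)(F)F`, 12300 nM in this assay.

Compound 2 sits at the limit of > 150000 nM in this assay, at which 2 of the 3 values shown sit, and no number is known for it. Compound 4 `CCOC(=O)C1=Cc2ccccc2OC1(OCc1cn(CC(=O)Nc2cccc(Cl)c2)nn1)C(F)(F)F` differs from compound 2 by chloro in place of fluoro on an aromatic carbon. Among the compounds with values here, the one measured step, an at least 12-fold lower number from compound 1 to compound 3 (1.08 log units; beyond the scatter), brings chloro onto an aromatic carbon too, but in place of methoxy rather than fluoro, so it bears only loosely on this change. From a limit, any step in this assay can only be read as a direction. The step from compound 2 to compound 4 is estimated as a number no higher from compound 2 to compound 4 (the limit leaves the size open). Compound 4 is expected to give about 150000 nM, between 30000 nM and 600000 nM.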

Compound 4, half-maximal inhibitory concentration: 12300 nM
The estimate for compound 4 lay 12-fold (1.09 log units) above the measured number; measured number below the stated range.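

In this assay, the change from 3-fluorophenyl to 3-chlorophenyl gives an at least 12-fold lower number from compound 2 to compound 4 (1.08 log units; beyond the scatter). The earlier step had shown chloro acting only in place of methoxy, whereas here chloro in place of fluoro, on an aromatic carbon meta to a large group, also lowers the number. The full size of this step stays unknown because compound 2 is a limit and not a number: the limit of > 150000 nM in this assay, at which 2 of the 4 values shown sit.

On these data alone, whether bromo or a methyl group at this place would also give a lower number remains open. So does whether chloro elsewhere on this ring would do the same.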